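The compounds below may be only part of what the source reports. "The series", "measured", "known", "first", "only" and "open" are said of these compounds alone.

Compound 1 `O=C1C(Nc2ccc(F)cc2)=CC(=O)c2ncccc21` reaches 79% in a functional assay on the whole organism (aorta) with Rattus norvegicus as the target; on this read-out higher numbers stand for larger maximal responses and lower numbers for smaller maximal responses. Compound 2 `O=C1C(Nc2ccc(F)c(F)c2)=CC(=O)c2ncccc21` differs from it by one change, (fluoro in place of hydrogen on an aromatic carbon), and this gave a number 13 percentage points higher from compound 1 to compound 2 (beyond the scatter). In this assay compound 2 gives 92%. Compound 3 `O=C1C=C(Nc2cccc(F)c2)C(=O)c2cnccc21` has the same atoms as compound 1 joined differently; the difference between the two cores is not broken down here. In this assay compound 3 gives 89%, which lies within the scatter of both compound 2 and compound 1. Compound 4 `O=C1C=C(Nc2cc(F)cc(F)c2)C(=O)c2cnccc21` arises from compound 3 by the same kind of change: fluoro in place of hydrogen on an aromatic carbon. The surroundings are not identical, since in compound 2 the entering fluoro sits ortho to a fluoro group, whereas in compound 4 it sits meta to a fluoro group; in both it is meta to a large group. The step from compound 3 to compound 4 in this assay is expected to be a number 6 percentage points higher from compound 3 to compound 4 (within the scatter), smaller than the earlier one because compound 3 already gives 89%, close to the top of the scale. Compound 4 is therefore estimated at 95%, between 85% and 104%.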

Compound 4, largest response reached (Emax), in percent of the reference or control that the assay uses: 94%
For compound 4 the middle estimate is 1 percentage points above the measured one; the measured number falls inside the stated range.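

Replacing a hydrogen with a fluoro on the carbon-only aromatic ring gave a number 5 percentage points higher from compound 3 to compound 4 (within the scatter), so on this core the change does not move the number beyond what repeat measurements would vary by. Set beside the earlier step in this assay, the two results cannot be told apart: the same change on two cores in this assay, a number 13 percentage points higher (beyond the scatter) from compound 1 to compound 2 and a number 5 percentage points higher (within the scatter) from compound 3 to compound 4, 8 percentage points apart, within the scatter of two such steps. Among the compounds shown here, this means nothing here argues against carrying the change from one core to the other, but it does not prove that the change acts alike on both, as each core offers only a single pair and the entering fluoro has different surroundings in the two pairs.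

The aromatic ring carries only fluoro groups in the compounds shown, so it remains open how a methoxy group, a trifluoromethyl group or a carboxylic acid would behave in the same place on either core. From the compounds shown here alone, it is also open whether the two cores would respond alike to a change elsewhere in the molecule, such as a methyl group on the nitrogen that links the ring to the core.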